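Pyridine Ring in Place of a Methyl on One Ester

The source may report more compounds than this note shows. Statements on the series, on what has been measured and on what is new or still open speak of the compounds shown alone.

Compound 1 `C=C1[C@H](OC(C)=O)C[C@@H](OC(C)=O)C(C)(C)/C=C/[C@@H](C)C(=O)[C@@]2(OC(C)=O)C[C@@](C)(OC(C)=O)[C@H](OC(C)=O)[C@@H]2[C@H]1OC(C)=O` gives 26.7% in a functional assay on HeLa cells (Homo sapiens) for inhibition, read by MTT assay, with a stated time of 72 h, tested at 30 ug/mL (a higher number here means more inhibition of growth at the concentration tested, a lower number less inhibition of growth), and no other number measured here stands above it. Compound 2 `C=C1[C@H](OCC(C)C)[C@@H](OC(C)=O)[C@@H](OC(C)=O)C(C)(C)[C@@H]2O[C@](O)([C@H](C)[C@@H]2OC(C)=O)[C@@]2(OC(C)=O)C[C@@](C)(OC(C)=O)[C@H](OC(C)=O)[C@@H]2[C@H]1OC(C)=O` gives 17.8% in this assay, a gap to compound 1 that lies within the usual scatter, so the two read as alike. Compound 3 `C=C1[C@H](OC(C)=O)C[C@@H](OC(=O)c2cccnc2)C(C)(C)/C=C/[C@@H](C)C(=O)[C@@]2(OC(C)=O)C[C@@](C)(OC(C)=O)[C@H](OC(C)=O)[C@@H]2[C@H]1OC(C)=O` differs from compound 1 in one place: pyridin-3-yl in place of methyl on a carbonyl carbon. For the measured compounds named here, no step between measured compounds is known, so nothing shows how large such a change runs. The step of a number 0.3 percentage points higher from compound 1 to compound 3 (within the scatter) is expected to stay within the scatter. Compound 3 is estimated at 27%, in a range from 12% to 42%.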

Compound 3, percent growth inhibition at one concentration: 17.9%
Estimate against measurement, compound 3: 9.1 percentage points above; measured number inside the range.
By their numbers in this assay, from the lowest: compounds 2, 3 and 1 (each within the scatter of the next).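

In this assay, for the compounds shown here, the ester at this position gives the first measured step between two compounds that differ in one place: a number 8.8 percentage points lower from compound 1 to compound 3 (within the scatter). Exchanging acetyl for (pyridin-3-yl)carbonyl, which adds an aromatic ring, therefore leaves compound 3 reading alike with compound 1 in this assay. No measurement shown here offers an explanation for this result. Still open, going by these compounds, is whether a phenyl ring, a longer chain or an amine on this carbonyl carbon would give a number beyond the scatter from compound 1.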